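From Cyclopentyl to Cyclohexyl on the Carbonyl Carbon

The source may hold more compounds than are shown below. What is called first, only, known or untested is meant among the compounds shown, and "the series" means these compounds.

Measured in an assay on isolated protein for inhibition of Nitric oxide synthase, inducible (Homo sapiens), read by scintillation counting, with a stated time of 30 min, tested at 50 uM (on this read-out lower numbers stand for less inhibition and higher numbers for more inhibition at the one concentration tested (going by the name of the read-out)), so far:
Compound 1 `CC(=O)N1N=C(c2ccccc2N)SC1(C)C` gives 22.9%
Compound 2 `CCCCC(=O)N1N=C(c2ccccc2N)SC1(C)C` gives 39.1%
Compound 3 `CC1(C)SC(c2ccccc2N)=NN1C(=O)C1CCCC1` gives 42.2%

Compound 3 has the highest number of the three, although its gap to compound 2 is within the scatter: a number 3.1 percentage points higher from compound 2 to compound 3 (within the scatter). Against compound 1 it stands clearly apart: a number 19.3 percentage points higher from compound 1 to compound 3 (beyond the scatter). Compound 4 `CC1(C)SC(c2ccccc2N)=NN1C(=O)C1CCCCC1` differs from compound 3 in one place: cyclohexyl in place of cyclopentyl on a carbonyl carbon. For the measured compounds named here, the steps that bear on this all enlarge the group on the carbonyl carbon. a number 16.2 percentage points higher from compound 1 to compound 2 (beyond the scatter) and a number 19.3 percentage points higher from compound 1 to compound 3 (beyond the scatter) show that growing beyond the smallest group raised inhibition, but a number 3.1 percentage points higher from compound 2 to compound 3 (within the scatter) shows that exchanging one larger group for another changed little. Compound 4 is therefore expected to stay near compound 3, with a number 2.8 percentage points higher from compound 3 to compound 4 (within the scatter). The estimate for compound 4 is 45%, ranging from 30% to 60%.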

Compound 4, a percentage reported as inhibition, at one concentration (the size of the read-out at that concentration, not a potency): 28%
Compound 4: the middle estimate sits 17 percentage points above what was measured; the measured number lies below the stated range.
By their numbers in this assay, from the lowest: compounds 1 and 4 (each within the scatter of the next); then compounds 2 and 3 (each within the scatter of the next).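

Enlarging the group on this carbonyl carbon does not steadily raise inhibition: exchanging one ring for a slightly larger one reverses the trend (a number 14.2 percentage points lower from compound 3 to compound 4 (beyond the scatter)). Cyclohexyl also falls short of the open-chain butyl (a number 11.1 percentage points lower from compound 2 to compound 4 (beyond the scatter)), so the two larger groups that looked alike earlier do not speak for all larger groups, and the gain over methyl is lost (a number 5.1 percentage points higher from compound 1 to compound 4 (within the scatter)). Nothing shown here explains this drop. Going by these compounds, it remains open whether a phenyl ring, a cycloheptyl ring or a branched tert-butyl group would follow cyclopentyl or cyclohexyl.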